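The source may hold more compounds than are shown below. What is called first, only, known or untested is meant among the compounds shown, and "the series" means these compounds.

Measured compounds:
- Compound 1, `COc1ccc(-c2nc3ccccn3c2/C=C/C(=O)c2cc(OC)c(OC)c(OC)c2)cc1`: 2940 nM in a functional assay on RXF 393 cells (Homo sapiens) for inhibition, read by sulforhodamine B assay, with a stated time of 48 h; a lower number here means a stronger inhibitor of growth, a higher number a weaker inhibitor of growth
- Compound 2, `COc1cc(C(=O)/C=C/c2c(-c3ccc(F)cc3)nc3ncccn23)cc(OC)c1OC`: 1440 nM in this assay

In this assay compound 2 gives 1440 nM, the lowest of the two numbers shown. Its nearest neighbour is compound 1, which in this assay gives 2940 nM; that gap lies beyond the usual scatter of the measurement. Compound 1 and compound 2 differ both in the shared core and in the group on the pendant phenyl ring, so no single change accounts for the difference between them.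

Among the compounds with values here, compound 3, `COc1ccc(-c2nc3ncccn3c2/C=C/C(=O)c2cc(OC)c(OC)c(OC)c2)cc1`, keeps the core of compound 2 and changes only one group: methoxy in place of fluoro on an aromatic carbon. The two compounds already measured do not isolate this change, so the expectation rests on the direction the numbers show. Compound 3 is expected to come in somewhat weaker than compound 2, with a step of a 1.5-fold higher number from compound 2 to compound 3 (0.18 log units; within the scatter) that may well fall within the scatter. The estimate for compound 3 is 2200 nM, with a range from 900 nM to 5000 nM.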

Compound 3, concentration for 50% growth inhibition: 1110 nM
Beside the measured number, compound 3's estimate is 2.0-fold (0.30 log units) above it; the measured number falls inside the stated range.
By their numbers in this assay, from the lowest: compounds 3 and 2 (each within the scatter of the next); then compound 1.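

With the core held fixed, methoxy in place of fluoro, para to a large group, gives a 1.3-fold lower number from compound 2 to compound 3 (0.11 log units; within the scatter) in this assay, so at this position the 4-fluorophenyl and 4-methoxyphenyl compounds cannot be told apart in this measurement. Nothing available explains why these two groups read alike here. Compound 3 also carries the 4-methoxyphenyl group of compound 1, so those two now differ only in the core: compound 1 gives 2940 nM, and compound 3 gives 1110 nM.

Going by these compounds, whether an amine, a carboxylic acid or a longer alkoxy chain at this position would move the number beyond the scatter remains open. So does whether fluoro and methoxy would also read alike on the core of compound 1.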